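Isopropyl in Place of the Amine Hydrogen

The source may report more compounds than this note shows. Statements on the series, on what has been measured and on what is new or still open speak of the compounds shown alone.

Compound 1 `CCCCN(c1ccc(OC)cc1)c1ncnc2occ(C)c12`: 100 nM
Compound 2 `COc1ccc(Nc2ncnc3occ(C)c23)cc1`: "not determined" (no result reported)

Two compounds were measured in a functional assay on MDA-MB-435 cells (Homo sapiens) for inhibition, read by sulforhodamine B assay, with a stated time of 48 h; on this read-out higher numbers stand for an effect only at larger amounts of compound and lower numbers for an effect already at smaller amounts. Compound 1 `CCCCN(c1ccc(OC)cc1)c1ncnc2occ(C)c12` gives 100 nM in this assay. Compound 2 `COc1ccc(Nc2ncnc3occ(C)c23)cc1` was also tested, but for compound 2 the result in this assay is "not determined" (no result reported), so no single number stands for it and nothing can be said of how it compares with compound 1.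

Compound 3 `COc1ccc(N(c2ncnc3occ(C)c23)C(C)C)cc1` is not yet measured. It differs from compound 2 in one place: isopropyl in place of hydrogen on a nitrogen on an aromatic ring. Within the data shown here, since compound 2 has no number in this assay, the size and direction of this step cannot be anchored on it; the only reference is compound 1, which carries a different group on the same nitrogen and gives 100 nM. On that basis compound 3 is expected to lie near that figure, with an estimated value of 150 nM in this assay, between 30 nM and 800 nM.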

Compound 3, half-maximal effective concentration: 504 nM
The estimate for compound 3 lay 3.4-fold (0.53 log units) below the measured number; low and high end bracket the measured number.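

In this assay, the change from butyl to isopropyl on the nitrogen gives a 5.0-fold higher number from compound 1 to compound 3 (0.70 log units; beyond the scatter). Among these compounds, this is the first readable step at this position, and it shows that the choice of group on this nitrogen moves the read-out beyond the usual scatter. Of the two groups compared here, butyl goes with the lower number, meaning an effect at smaller amounts of compound, but the compounds shown offer no measured explanation for the difference.

Going by these compounds, compound 2 has no number, so the steps from its hydrogen to butyl or to isopropyl cannot be read, and it remains open whether either group improves on the hydrogen. Also open, on these data alone, is where a longer chain such as hexyl, a cyclopropyl ring or a chain ending in an amine would fall on this nitrogen.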